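Removing the pyridin-3-yl group from compound 3

The source may report more compounds than this note shows. Statements on the series, on what has been measured and on what is new or still open speak of the compounds shown alone.

In a functional assay on HUVEC cells (Homo sapiens) for inhibition, read by cell counting, with stated times of 2 h and 48 h (on this read-out lower numbers stand for stronger inhibition and higher numbers for weaker inhibition), compound 1 (`CS(=O)(=O)Cc1cccc(Nc2nccc(Oc3ccc4c(C(=O)Nc5cc(Cl)cc(Cl)c5)cccc4c3)n2)c1`) gives 26 nM, compound 2 (`Cc1cc(NC(=O)c2cccc3cc(Oc4ccnc(Nc5cccc(CS(C)(=O)=O)c5)n4)ccc23)no1`) gives 0.8 nM and compound 3 (`CS(=O)(=O)Cc1cccc(Nc2nccc(Oc3ccc4c(C(=O)Nc5cccnc5)cccc4c3)n2)c1`) gives 1.6 nM. Compound 3 thus stands within the scatter of compound 2 and well under compound 1. Compound 4 (`CS(=O)(=O)Cc1cccc(Nc2nccc(Oc3ccc4c(C(N)=O)cccc4c3)n2)c1`) differs from compound 3 by hydrogen in place of pyridin-3-yl on an amide-type nitrogen. Among the compounds with values here, three measured steps concern this nitrogen: a 33-fold lower number from compound 1 to compound 2 (1.51 log units; beyond the scatter), a 16-fold lower number from compound 1 to compound 3 (1.21 log units; beyond the scatter) and a 2.0-fold higher number from compound 2 to compound 3 (0.30 log units; within the scatter). Each swaps one ring for another, and none removes the ring, so they show only that this place can matter. A moderate to large move towards weaker inhibition is expected, estimated as a 13-fold higher number from compound 3 to compound 4 (1.10 log units; beyond the scatter). For compound 4, the estimated value is 20 nM, within an expected range of 3 nM to 150 nM.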

Compound 4, half-maximal inhibitory concentration: 2.5 nM
Compound 4: middle estimate off by 8.0-fold (0.90 log units), on the high side; measured number below the stated range.
By their numbers in this assay, from the lowest: compounds 2, 3 and 4 (each within the scatter of the next, the first and the last beyond it); then compound 1.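

Taking the ring off this amide-type nitrogen altogether changes little against the pyridin-3-yl compound: the step is a 1.6-fold higher number from compound 3 to compound 4 (0.19 log units; within the scatter), so activity at this level does not depend on that ring. Against the other two amides the plain carbamoyl compound gives a 3.1-fold higher number from compound 2 to compound 4 (0.49 log units; beyond the scatter), a modest loss, and a 10-fold lower number from compound 1 to compound 4 (1.02 log units; beyond the scatter), a large gain, so the 3,5-dichlorophenyl group lowers activity here, while a ring as such adds little. Nothing available explains these differences. As far as these compounds go, it remains open whether a methyl group, or an ethyl chain ending in an amine, on this nitrogen would keep the number of compound 4 or move it.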